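Shortening the Ether Chain Again: From Isopropyl to Vinyl

The source may report more compounds than this note shows. Statements on the series, on what has been measured and on what is new or still open speak of the compounds shown alone.

Compound 2 `CC(C)COc1ccccc1C1CC(=O)c2ccccc2O1` stands lowest of the two compounds measured in a functional assay on RAW264.7 cells (Mus musculus) for inhibition, read by immunoassay, with a stated time of 12 h, tested at 30 uM; on this read-out higher numbers stand for more inhibition at the one concentration tested (going by the name of the read-out) and lower numbers for less inhibition. Within the data shown here, compound 1 `CC(C)CCOc1ccccc1C1CC(=O)c2ccccc2O1` gives 47.6%, whereas compound 2 gives 30.4%, and the single measured step, a number 17.2 percentage points lower from compound 1 to compound 2 (beyond the scatter), is the only guide available. Compound 3 `C=CCOc1ccccc1C1CC(=O)c2ccccc2O1` differs from compound 2 by vinyl in place of isopropyl on a saturated chain carbon bound to an oxygen on an aromatic ring. This is again a shortening of the chain at the same place, so the measured step bears on it directly, though it does not show whether a second cut continues in the same direction. Among the measured compounds shown here, the drop seen in the first step suggests a further fall, but with only one step in hand the outcome could also stay within the scatter. The expected change is a number 8.4 percentage points lower from compound 2 to compound 3 (within the scatter). Compound 3 is therefore estimated to give 22%, with a range from 5% to 40%.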

Compound 3, a percentage reported as inhibition, at one concentration (the size of the read-out at that concentration, not a potency): 49.3%
For compound 3 the middle estimate is 27.3 percentage points below the measured one; measured number above the stated range.
By their numbers in this assay, from the lowest: compound 2; then compounds 1 and 3 (each within the scatter of the next).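

In this assay, vinyl in place of isopropyl on a saturated chain carbon bound to an oxygen on an aromatic ring gives a number 18.9 percentage points higher from compound 2 to compound 3 (beyond the scatter) at this same place, so the read-out does not simply follow the shortening of the chain. Set against compound 1, the same group gives a number 1.7 percentage points higher from compound 1 to compound 3 (within the scatter) and the two cannot be told apart here, even though vinyl has fewer heavy atoms than isobutyl and carries a double bond. Among these three compounds it is compound 2 alone that stands apart, with compounds 1 and 3 on either side of a chain of its length.

As far as these compounds go, it remains open whether the double bond or the chain length governs this result, and what a saturated propyl chain, a propargyl group or a longer chain would give at this place on the shared core. Nothing shown here offers an explanation for the rise.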